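Replacing the 4-ethylpiperazin-1-yl group of compound 2

The source may report more compounds than this note shows. Statements on the series, on what has been measured and on what is new or still open speak of the compounds shown alone.

Measured in a functional assay on KYSE-450 cells (Homo sapiens) for inhibition, read by CCK-8 assay, with a stated time of 48 h (a lower number here means a stronger inhibitor, a higher number a weaker inhibitor), so far:
compound 1 `COc1ccc(CN(C(=O)CSc2nc3ccccc3o2)c2cc(OC)c(OC)c(OC)c2)cc1` gives 840 nM
compound 2 `CCN1CCN(C(=S)SCC(=O)N(Cc2ccc(OC)cc2)c2cc(OC)c(OC)c(OC)c2)CC1` gives 3070 nM
compound 3 `COc1ccc(CN(C(=O)CSC(=S)N2CCN(Cc3ccc(C(C)(C)C)cc3)CC2)c2cc(OC)c(OC)c(OC)c2)cc1` gives 2140 nM

Compound 2, at 3070 nM, lies within the scatter of compound 3 and clearly above compound 1. The change followed here leads to compound 4 `COc1ccc(CN(C(=O)CSC(=S)N2CCc3cc(Br)ccc32)c2cc(OC)c(OC)c(OC)c2)cc1` and places 5-bromo-2,3-dihydro-1H-indol-1-yl in place of 4-ethylpiperazin-1-yl on a thiocarbonyl carbon.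

For the measured compounds named here, two measured steps bear on this change. With 4-(tert-butyl)phenyl in place of methyl, compound 3 gives no shift beyond the scatter (a 1.4-fold lower number from compound 2 to compound 3 (0.16 log units; within the scatter)), so that step offers no reason to expect movement. Compound 1 has a group with a six-membered aromatic ring of carbon only on a sulfur, and the difference there is modest (a 3.7-fold higher number from compound 1 to compound 2 (0.56 log units; beyond the scatter)). Going by the values given here, compound 4 also brings a six-membered aromatic ring of carbon only, although the two groups differ and no measured step covers the bromine. A modest move toward a lower number in this assay therefore seems likely, without reaching compound 1 with any certainty. The expected step is a 2.2-fold lower number from compound 2 to compound 4 (0.34 log units; beyond the scatter), and it carries wide uncertainty. The estimated value for compound 4 is 1400 nM, with an expected range from 550 nM to 3800 nM.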

Compound 4, half-maximal inhibitory concentration: > 20000 nM
Compound 4 was reported as a limit (the forecaster's own chance of this, stated with the estimate: 3%); at least 14-fold (1.15 log units) between middle value and limit.
By their numbers in this assay, from the lowest: compound 1; then compounds 3 and 2 (each within the scatter of the next). At a limit, above all of these: compound 4.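

Compound 4 has no number in this assay, only a limit: the limit of > 20000 nM in this assay, at which 1 of the 4 values shown sits. Among the compounds shown, the group on the thiocarbonyl carbon had so far made little difference, with a 1.4-fold lower number from compound 2 to compound 3 (0.16 log units; within the scatter) on the piperazine, but exchanging the 4-ethylpiperazin-1-yl group itself for 5-bromo-2,3-dihydro-1H-indol-1-yl gives an at least 6.5-fold higher number from compound 2 to compound 4 (0.81 log units; beyond the scatter), so this position is far less forgiving than that earlier step suggested. The comparison with the benzoxazole-free side of the series also changes: an at least 23-fold higher number from compound 1 to compound 4 (1.37 log units; beyond the scatter), so a six-membered aromatic ring of carbon only, present in the group on sulfur in both of these compounds, does not by itself keep the activity of compound 1.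

The compounds shown do not separate the bromine from the ring that carries it, since both enter together, so the unsubstituted 2,3-dihydro-1H-indol-1-yl group would be needed to tell which of the two goes with the loss. A piperidine or morpholine on the same thiocarbonyl carbon would show whether the second ring nitrogen of the piperazine matters, which these compounds leave open.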